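This account rests on a few compounds, and the source may have more. Where it says the series, first, only, none or still open, it means among the compounds named here.

Measured so far in an ADME assay on microsomes from liver (Homo sapiens) for metabolic stability, read by LC-MS, using NADPH, tested at 3 uM; on this read-out higher numbers stand for a longer-lived compound and lower numbers for a shorter-lived compound:
compound 1 `N#CCC(c1ccccc1)c1c(-c2ccccc2)[nH]c2cc(Cl)ccc12`: 0.72 h
compound 2 `Cc1ccc2c(C(CC(F)(F)F)c3ccccc3)c(-c3ccccc3)[nH]c2c1`: 1.45 h
compound 3 `FC(F)(F)CC(c1ccco1)c1c(-c2ccccc2)[nH]c2cc(Cl)ccc12`: 1.07 h

Compound 3 at 1.07 h stands in the middle of the three numbers, within the scatter of both compound 1 and compound 2. Compound 4 `FC(F)(F)CC(c1ccccc1)c1c(-c2ccccc2)[nH]c2cc(Cl)ccc12` is not yet measured. Its change from compound 3 reads phenyl in place of furan-2-yl on a saturated chain carbon bound to an aromatic carbon and a saturated chain carbon and amounts to phenyl in place of furan-2-yl on a saturated chain carbon bound to an aromatic carbon and a saturated chain carbon. Within the data shown here, no measured pair isolates this change in this assay so far. Compound 2 at 1.45 h and compound 1 at 0.72 h both carry phenyl there, and neither lies beyond the scatter from compound 3. The expected step of a 1.1-fold higher number from compound 3 to compound 4 (0.05 log units; within the scatter) is therefore none beyond the scatter. Compound 4 is estimated at 1.2 h with an expected range of 0.6 h to 2.4 h in this read-out.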

Compound 4, half-life: 1.64 h
Estimate against measurement, compound 4: 1.4-fold (0.14 log units) below; low and high end bracket the measured number.
By their numbers in this assay, from the lowest: compounds 1, 3, 2 and 4 (each within the scatter of the next, the first and the last beyond it).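

In this assay, the first pair isolating phenyl in place of furan-2-yl on this saturated chain carbon gives a 1.5-fold higher number from compound 3 to compound 4 (0.19 log units; within the scatter), so this change does not separate the two rings. Chloro in place of methyl on an aromatic carbon gives a 1.1-fold higher number from compound 2 to compound 4 (0.05 log units; within the scatter), while trifluoromethyl in place of cyano on a saturated chain carbon gives the only step beyond the scatter, a 2.3-fold higher number from compound 1 to compound 4 (0.36 log units; beyond the scatter). Nothing available explains these steps.

Still open, on these data alone, is how a saturated amine in place of the ring on that carbon would read, and whether a longer chain in place of trifluoromethyl would keep the number of compound 4.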